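This account rests on a few compounds, and the source may have more. Where it says the series, first, only, none or still open, it means among the compounds named here.

Measured so far:
Compound 1, `O=C(O)c1ccc(S(=O)(=O)N2CCC(NS(=O)(=O)c3cc(S(=O)(=O)c4ccccc4)ccc3C(F)(F)F)CC2)cc1`, in an assay on isolated protein for displacement of a labelled ligand from secreted frizzled-related protein 1 (Homo sapiens), read by fluorescence polarization, with a stated time of 30 min (a lower number here means a stronger inhibitor, a higher number a weaker inhibitor), compound 1 gives 20 nM.
Compound 2, `CC(C)(C)OC(=O)N1CCC(CC(=O)N2CCC(NS(=O)(=O)c3cc(S(=O)(=O)c4ccccc4)ccc3C(F)(F)F)CC2)CC1`, in this assay compound 2 gives 490 nM.

Compound 2 stands highest of the two numbers, with a value of 490 nM. Compound 1 gives 20 nM, and the gap between the two is well beyond the scatter. Compound 3, `O=C(CC1CCNCC1)N1CCC(NS(=O)(=O)c2cc(S(=O)(=O)c3ccccc3)ccc2C(F)(F)F)CC1`, differs from compound 2 in one place: hydrogen in place of tert-butoxycarbonyl on an amine nitrogen in a ring. Among the measured compounds shown here, no measured pair shows this kind of change, so the direction is open. A modest step toward a lower number is expected, within a 1.6-fold lower number from compound 2 to compound 3 (0.21 log units; within the scatter), since the shared core of compound 1 tolerates a different end group. Compound 3 is expected to give 300 nM, in the range 60 nM to 1500 nM.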

Compound 3, half-maximal inhibitory concentration: 100 nM
Beside the measured number, compound 3's estimate is 3.0-fold (0.48 log units) above it; low and high end bracket the measured number.
By their numbers in this assay, from the lowest: compound 1; then compound 3; then compound 2.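

In this assay, hydrogen in place of tert-butoxycarbonyl on the amine nitrogen in the ring gives a 4.9-fold lower number from compound 2 to compound 3 (0.69 log units; beyond the scatter) and shows that the group at this nitrogen matters. The end group of compound 1 still does better: ((piperidin-4-yl)methyl)carbonyl in place of (4-carboxyphenyl)sulfonyl gives a 5.0-fold higher number from compound 1 to compound 3 (0.70 log units; beyond the scatter) on the same shared core. Nothing available explains either step. Open, going by these compounds, is whether a methyl or acetyl group on that nitrogen would hold the lower number. Also open, on these data alone, is whether a carboxylic acid there would approach compound 1.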